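Aryl swap on the alkyne of the shared core

A few compounds are considered here, and "the series" means these few. Any claim that something is new, unique, unknown or untested is made for them only; others in the source may bear on it.

Compound 1 `COC(=O)c1sc2cc(C#Cc3cccc(N)c3)cnc2c1N` gives 10800 nM in a functional assay on MCF7 cells (Homo sapiens) for inhibition, read by sulforhodamine B assay, with a stated time of 48 h; a higher number here means a weaker inhibitor of growth, a lower number a stronger inhibitor of growth.
Compound 2 `COC(=O)c1sc2cc(C#Cc3ccccc3OC)cnc2c1N` is reported in this assay only as a limit, > 47300 nM.

Compound 2 therefore stands at the limit of this assay (the limit of > 47300 nM in this assay, at which 1 of the 2 values shown sits), and its true number is not known beyond that. Within the data shown here, the one measured step, an at least 4.3-fold higher number from compound 1 to compound 2 (0.64 log units; beyond the scatter), shows that the group on the triple-bonded carbon can shift the number by at least a modest amount, with compound 2 at the weaker end.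

Compound 3 `COC(=O)c1sc2cc(C#Cc3cccnc3)cnc2c1N` differs from compound 2 by pyridin-3-yl in place of 2-methoxyphenyl on a triple-bonded carbon. Among the measured compounds shown here, the measured step bears on this change only loosely: it fixes compound 2 as weaker than compound 1 but does not size the gap, and pyridin-3-yl has no measured counterpart. A downward step from compound 2 to compound 3 is expected, an at least 1.8-fold lower number from compound 2 to compound 3 (0.27 log units; that floor lies within the scatter), but its size is uncertain. Compound 3 is estimated at 25000 nM, with a range from 8000 nM to 80000 nM.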

Compound 3, concentration for 50% growth inhibition: > 150000 nM
Compound 3 gave a limit, no number; the forecaster's own chance of this, stated with the estimate: 40%; at least 6.0-fold (0.77 log units) between middle value and limit.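

Compound 3 is reported only as a limit in this assay: the limit of > 150000 nM in this assay, at which 1 of the 3 values shown sits.

Pyridin-3-yl in place of 3-aminophenyl gives an at least 13-fold higher number from compound 1 to compound 3 (1.14 log units; beyond the scatter), a large step, so of the three aromatic groups on the triple-bonded carbon only 3-aminophenyl has given a number so far. Compound 2 and compound 3 both rest on limits, and the step between them cannot be read.

Still open, from the compounds shown here alone, is whether the amine of 3-aminophenyl or its carbon ring sets the number for compound 1, and how far compound 2 and compound 3 truly lie from it. A plain phenyl, a 3-hydroxyphenyl or an aminopyridinyl group on the triple-bonded carbon would bear on the first question.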